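A few compounds are considered here, and "the series" means these few. Any claim that something is new, unique, unknown or untested is made for them only; others in the source may bear on it.

Of the compounds shown here, three that share one core have been tested in a functional assay on MIA PaCa-2 cells (Homo sapiens) for inhibition, read by MTT assay, with a stated time of 48 h, tested at 10 uM; a higher number here means more inhibition of growth at the concentration tested, a lower number less inhibition of growth. In this test, compound 1 `Cc1oc2c([C@H]3CCN(C)C[C@H]3O)c(O)cc(O)c2c(=O)c1C(O)c1ccccc1Br` gives 10%, compound 2 `CCOc1ccc(Br)c(C(O)c2c(C)oc3c([C@H]4CCN(C)C[C@H]4O)c(O)cc(O)c3c2=O)c1` gives 4%, and compound 3 `Cc1oc2c([C@H]3CCN(C)C[C@H]3O)c(O)cc(O)c2c(=O)c1C(O)c1cccc(Cl)c1Cl` gives 2%. Compound 3 therefore stands within the scatter of both other compounds, and the three numbers cannot be told apart.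

The next compound is compound 4 `Cc1oc2c([C@H]3CCN(C)C[C@H]3O)c(O)cc(O)c2c(=O)c1C(O)c1ccc(F)cc1`. It has 4-fluorophenyl in place of 2,3-dichlorophenyl on a saturated chain carbon bound to an aromatic carbon and an oxygen on a saturated carbon, while the shared core stays the same: 4-fluorophenyl in place of 2,3-dichlorophenyl on a saturated chain carbon bound to an aromatic carbon and an oxygen on a saturated carbon.

The most relevant measured steps exchange the group at this same place, and they show a number 8 percentage points lower from compound 1 to compound 3 (within the scatter) and a number 2 percentage points lower from compound 2 to compound 3 (within the scatter). The remaining step, an ethoxy in place of hydrogen on an aromatic carbon, shows a number 6 percentage points lower from compound 1 to compound 2 (within the scatter). Within the data shown here, all three steps are small, but no tested compound carries 4-fluorophenyl, so the evidence is thin. On this basis, the estimated step is a number 4 percentage points higher from compound 3 to compound 4 (within the scatter), which means no real change beyond the scatter is expected. Compound 4 is estimated at 6%, with an expected range from 0% to 18%.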

Compound 4, percent growth inhibition at one concentration: 17%
Estimate against measurement, compound 4: 11 percentage points below; the range from low to high includes it.
By their numbers in this assay, from the lowest: compounds 3, 2, 1 and 4 (each within the scatter of the next, the first and the last beyond it).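

In this assay, among these compounds, the group on the saturated chain carbon bound to an aromatic carbon and an oxygen on a saturated carbon now proves able to move the number beyond the scatter, which no step among the earlier compounds did: a number 15 percentage points higher from compound 3 to compound 4 (beyond the scatter), and a number 13 percentage points higher from compound 2 to compound 4 (beyond the scatter). The gain is not seen against every group, however, since the 2-bromophenyl compound stays close, with a number 7 percentage points higher from compound 1 to compound 4 (within the scatter), so 4-fluorophenyl cannot be told apart from 2-bromophenyl here. No measurement shown bears on the cause of these steps.

The change from 2,3-dichlorophenyl to 4-fluorophenyl alters both the kind of halogen and how many halogens the ring carries, and it also moves the substitution, so the compounds shown cannot separate these changes from one another. As far as these compounds go, it remains open how a plain phenyl, a 4-chlorophenyl or a 4-aminophenyl at this place would read, and whether any such group would rise clearly above compound 4 at 17%.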